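A few compounds are considered here, and "the series" means these few. Any claim that something is new, unique, unknown or untested is made for them only; others in the source may bear on it.

Compound 1 `Cc1cn2c(-c3cn[nH]c3)cnc2c(Nc2cc(Cc3ncccn3)ns2)n1` is the starting point. In an ADME assay on the whole organism for pharmacokinetics, with Rattus norvegicus as the target, with a stated time of 6 h, at a dose of 10 mg/kg by the oral route (a lower number here means less compound in the circulation, a higher number more compound in the circulation at the dose given), compound 1 gives 701 ng.h/mL, the lowest of the two numbers available. Compound 2 `Cc1cn2c(-c3cn[nH]c3)cnc2c(Nc2cc(Cc3ccccn3)ns2)n1` gives 6880 ng.h/mL in this assay, and the change from compound 1 to compound 2 brought a 9.8-fold higher number from compound 1 to compound 2 (0.99 log units; beyond the scatter). Compound 3 `Cc1cn2c(-c3cn[nH]c3)cnc2c(Nc2cc(Cc3cccnc3)ns2)n1` was also prepared, but in this assay compound 3 stands as "not determined" (no result reported), so no number is available for it. Compound 4 `Cc1ccnc(Cc2cc(Nc3nc(C)cn4c(-c5cn[nH]c5)cnc34)sn2)c1` differs from compound 1 by 4-methylpyridin-2-yl in place of pyrimidin-2-yl on a saturated chain carbon bound to an aromatic carbon. Within the data shown here, the only measured step that bears on this change is the one from compound 1 to compound 2, where pyridin-2-yl likewise replaced pyrimidin-2-yl; compound 4 carries a methyl group on that pyridine in addition. An increase is therefore expected, of about a 5.7-fold higher number from compound 1 to compound 4 (0.76 log units; beyond the scatter). Compound 4 is estimated at 4000 ng.h/mL, with a range from 1000 ng.h/mL to 15000 ng.h/mL.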

Compound 4, area under the concentration-time curve: 1850 ng.h/mL
Compound 4: middle estimate off by 2.2-fold (0.33 log units), on the high side; the measured number falls inside the stated range.
By their numbers in this assay, from the lowest: compound 1; then compound 4; then compound 2.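

In this assay, the methyl group has a measurable effect at this position: methyl in place of hydrogen on an aromatic carbon lowers the number (a 3.7-fold lower number from compound 2 to compound 4 (0.57 log units; beyond the scatter)). The pyridin-2-yl gain is therefore only partly kept, yet 4-methylpyridin-2-yl in place of pyrimidin-2-yl still raises it (a 2.6-fold higher number from compound 1 to compound 4 (0.42 log units; beyond the scatter)). The result thus depends on a group on the ring as well as on the ring itself, and nothing at hand gives a cause for either step. As far as these compounds go, it remains open whether this fall belongs to methyl alone or would also follow with a fluorine, a methoxy group or a longer chain on the pyridine ring.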